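Working notes: amine exchange on compound 2

A few compounds are considered here, and "the series" means these few. Any claim that something is new, unique, unknown or untested is made for them only; others in the source may bear on it.

Measured in a functional assay on BCG823 cells (Homo sapiens) for antiproliferative activity, read by MTT assay, with a stated time of 48 h; on this read-out lower numbers stand for stronger inhibition and higher numbers for weaker inhibition:
compound 1 `COc1cc2oc(-c3ccccc3)cc(=O)c2c(O)c1OCCCCN1CCN(C)CC1`: 53500 nM
compound 2 `O=c1cc(-c2ccccc2)oc2cc(OCc3ccccc3)c(OCCCN3CCCC3)c(O)c12`: > 100000 nM
compound 3 `COc1cc2oc(-c3ccccc3)cc(=O)c2c(O)c1OCCCN1CCCC1`: 6500 nM

Compound 2 gives only a limit of this assay, > 100000 nM, not a number. Compound 4 `CN1CCN(CCCCOc2c(OCc3ccccc3)cc3oc(-c4ccccc4)cc(=O)c3c2O)CC1` differs from compound 2 by (4-methylpiperazin-1-yl)methyl in place of pyrrolidin-1-yl on a saturated chain carbon, three bonds along the chain from an oxygen on an aromatic ring. The step from compound 2 to compound 3 concerns a different change and does not bear here. Within the data shown here, the one measured step on this exchange runs the other way, an 8.2-fold lower number from compound 1 to compound 3 (0.92 log units; beyond the scatter); reversed, it points to a higher number for compound 4, of about that size. Compound 2 already stands at the limit of > 100000 nM in this assay, at which 1 of the 3 values shown sits, so a higher number cannot be resolved. Compound 4 is expected to remain at the limit, with an estimated 300000 nM (range 100000 nM to 1000000 nM). The expected step is a step that the limit leaves unreadable from compound 2 to compound 4.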

Compound 4, half-maximal inhibitory concentration: 7200 nM
The estimate for compound 4 lay 42-fold (1.62 log units) above the measured number; measured number below the stated range.
By their numbers in this assay, from the lowest: compounds 3 and 4 (each within the scatter of the next); then compound 1. At a limit, above all of these: compound 2.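

The exchange of pyrrolidin-1-yl for (4-methylpiperazin-1-yl)methyl gives an at least 13-fold lower number from compound 2 to compound 4 (1.14 log units; beyond the scatter), opposite in direction to the earlier step, so its outcome depends on the rest of the molecule: the same change on two cores in this assay, an 8.2-fold lower number (0.92 log units; beyond the scatter) from compound 1 to compound 3 and an at least 13-fold higher number (1.14 log units; beyond the scatter) from compound 4 to compound 2, at least 110-fold (2.05 log units) apart, beyond the scatter of two such steps. Phenyl in place of hydrogen on the saturated chain carbon bound to an oxygen on an aromatic ring gives a 7.4-fold lower number from compound 1 to compound 4 (0.87 log units; beyond the scatter) with the 4-(4-methylpiperazin-1-yl)butyl chain, while with the 3-(pyrrolidin-1-yl)propyl chain the same change goes the other way: the same change on two cores in this assay, an at least 15-fold lower number (1.18 log units; beyond the scatter) from compound 2 to compound 3 and a 7.4-fold higher number (0.87 log units; beyond the scatter) from compound 4 to compound 1, at least 110-fold (2.05 log units) apart, beyond the scatter of two such steps.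

Open, going by these compounds, is whether this reversal belongs to the amine or to the chain length. A 4-(pyrrolidin-1-yl)butyl chain or a 3-(4-methylpiperazin-1-yl)propyl chain on both cores would separate the two.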